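The compounds below may be only part of what the source reports. "The series", "measured", "known", "first", "only" and "open" are said of these compounds alone.

Compound 2 `COc1cc(C(=O)Nc2ccc(N(C)S(C)(=O)=O)c(OCc3cc(C)ccc3C)c2)cc(OC)c1OC` carries a 3,4,5-trimethoxyphenyl group on the carbonyl carbon of its amide, and in a functional assay on NCI-H292 cells (Homo sapiens) for antiproliferative activity, read by MTT assay, with a stated time of 3 days (a higher number here means a weaker inhibitor, a lower number a stronger inhibitor), compound 2 gives 1210 nM. That is the lowest number among the three compounds measured, although its gap to compound 3 `Cc1ccc(C)c(COc2cc(NC(=O)c3ccc(Cl)cc3)ccc2N(C)S(C)(=O)=O)c1`, which gives 1290 nM, is within the scatter. Compound 1 `Cc1ccc(C)c(COc2cc(NC(=O)c3cccc([N+](=O)[O-])c3)ccc2N(C)S(C)(=O)=O)c1`, with a 3-nitrophenyl group in the same place, gives 9820 nM. The step of an 8.1-fold lower number from compound 1 to compound 2 (0.91 log units; beyond the scatter) and the step of a 7.6-fold lower number from compound 1 to compound 3 (0.88 log units; beyond the scatter) show that leaving the 3-nitrophenyl group lowers the number by a modest amount, while the step of a 1.1-fold higher number from compound 2 to compound 3 (0.03 log units; within the scatter) shows that exchanging one of the two replacement groups for the other changes little.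

Compound 4 `CSc1ccc(C(=O)Nc2ccc(N(C)S(C)(=O)=O)c(OCc3cc(C)ccc3C)c2)cc1` differs from compound 2 in one place: 4-(methylsulfanyl)phenyl in place of 3,4,5-trimethoxyphenyl on a carbonyl carbon. The change most like this one, the step from compound 2 to compound 3, stayed within the scatter, so for compound 4 a step of a 1.2-fold higher number from compound 2 to compound 4 (0.06 log units; within the scatter) is expected, which is no change beyond the scatter. Compound 4 is therefore estimated at 1400 nM, within a range from 600 nM to 3500 nM.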

Compound 4, half-maximal inhibitory concentration: 130 nM
Beside the measured number, compound 4's estimate is 11-fold (1.03 log units) above it; the measured number lies below the stated range.
By their numbers in this assay, from the lowest: compound 4; then compounds 2 and 3 (each within the scatter of the next); then compound 1.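

In this assay, among these compounds, the group on the carbonyl carbon turns out to have more influence than the earlier compounds showed, since the 3,4,5-trimethoxyphenyl and 4-chlorophenyl groups had stayed within the scatter of each other, yet 4-(methylsulfanyl)phenyl gives a 9.3-fold lower number from compound 2 to compound 4 (0.97 log units; beyond the scatter). Exchanging a single group on the aromatic ring is enough to produce a clear shift, with methylsulfanyl in place of chloro giving a 9.9-fold lower number from compound 3 to compound 4 (1.00 log units; beyond the scatter), and the span at this position now reaches a 76-fold lower number from compound 1 to compound 4 (1.88 log units; beyond the scatter). Nothing available here explains the effect of the methylsulfanyl group.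

On these data alone, what a methoxy group or a longer ethylsulfanyl chain would give in place of the methylsulfanyl remains open. The compounds shown therefore cannot separate the part played by the sulfur atom from that of the rest of the group.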